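The compounds below may be only part of what the source reports. "The series", "measured", "known", "first", "only" and "open" are said of these compounds alone.

Of the compounds shown here, three have been measured in a functional assay on A549 cells (Homo sapiens) for inhibition, read by MTT assay; on this read-out higher numbers stand for weaker inhibition and lower numbers for stronger inhibition. Compound 1 `CCCCCCCCn1cc(/C=C/C(=O)c2ccc(NC(=O)CN3CCN(c4ccccc4)CC3)cc2)nn1` gives 52400 nM. Compound 2 `O=C(CN1CCN(c2ccccc2F)CC1)Nc1ccc(C(=O)/C=C/c2cn(Cc3ccc(Br)cc3)nn2)cc1` gives 14700 nM, and compound 3 `COc1ccccc1N1CCN(CC(=O)Nc2ccc(C(=O)/C=C/c3cn(Cc4ccc(Br)cc4)nn3)cc2)CC1` gives 34000 nM. Compound 3 thus stands second highest of the three numbers: its gap to compound 1 lies within the scatter, while the step from compound 2 to compound 3, a 2.3-fold higher number from compound 2 to compound 3 (0.36 log units; beyond the scatter), is a modest but real weakening that accompanies methoxy in place of fluoro on an aromatic carbon.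

Compound 4 `O=C(CN1CCN(c2ccccc2)CC1)Nc1ccc(C(=O)/C=C/c2cn(Cc3ccc(Br)cc3)nn2)cc1` arises from compound 3 by hydrogen in place of methoxy on an aromatic carbon, ortho to a large group. Among the compounds with values here, only that one measured step bears on this change, and it shows that the group at this position shifts the number by a modest amount. Compound 2 carries the small fluoro there and gives 14700 nM, whereas compound 3 with methoxy gives 34000 nM, so a bare hydrogen is expected to land between the two. Compound 4 is therefore estimated at 20000 nM in this assay, with a range from 8000 nM to 50000 nM. This estimate amounts to an expected 1.7-fold lower number from compound 3 to compound 4 (0.23 log units; within the scatter).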

Compound 4, half-maximal inhibitory concentration: 42100 nM
Compound 4: the middle estimate sits 2.1-fold (0.32 log units) below what was measured, and the stated range covers the measured number.
By their numbers in this assay, from the lowest: compound 2; then compounds 3, 4 and 1 (each within the scatter of the next).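

In this assay, hydrogen and methoxy on this aromatic carbon cannot be told apart (a 1.2-fold higher number from compound 3 to compound 4 (0.09 log units; within the scatter)), whereas fluoro now stands apart from hydrogen as well as from methoxy (a 2.9-fold higher number from compound 2 to compound 4 (0.46 log units; beyond the scatter)). Among these three groups, then, only the fluoro compound gives a distinctly lower number, so the earlier step reflects something about fluoro and not a general effect of any group placed here. Exchanging heptyl for 4-bromophenyl elsewhere in the molecule also leaves the number within the scatter (a 1.2-fold lower number from compound 1 to compound 4 (0.10 log units; within the scatter)), and no measurement at hand explains any of these results.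

Still open, from the compounds shown here alone, is how other groups on this carbon, such as chloro or an amine, would read. Going by these compounds, it is also open whether fluoro would give a lower number alongside heptyl.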